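Swapping One Chloro for Bromo in Compound 3

The source may report more compounds than this note shows. Statements on the series, on what has been measured and on what is new or still open speak of the compounds shown alone.

Three compounds that share one core and differ only in the group on the carbonyl carbon have been measured in a functional assay on C8166 cells (Homo sapiens) for cytotoxicity, read by MTT assay; a lower number here means that less compound is tolerated, a higher number that more compound is tolerated. Compound 1 `Cc1cc(S(N)(=O)=O)ccc1NC(=O)COc1ccc(Cl)cc1NC(=O)c1cccc(F)c1` gives 243000 nM, compound 2 `Cc1ccc(C)c(C(=O)Nc2cc(Cl)ccc2OCC(=O)Nc2ccc(S(N)(=O)=O)cc2C)c1` gives 79700 nM, and compound 3 `Cc1cc(S(N)(=O)=O)ccc1NC(=O)COc1ccc(Cl)cc1NC(=O)c1cc(Cl)cc(Cl)c1`, which carries a 3,5-dichlorophenyl group, gives 72400 nM. Replacing the group of compound 1 lowers the number modestly in both cases: a 3.4-fold lower number from compound 1 to compound 3 (0.53 log units; beyond the scatter), and a 3.0-fold lower number from compound 1 to compound 2 (0.48 log units; beyond the scatter). The remaining step, a 1.1-fold lower number from compound 2 to compound 3 (0.04 log units; within the scatter), shows no separation, so compound 3 shares the low end of this small set with compound 2.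

Compound 4 `Cc1cc(S(N)(=O)=O)ccc1NC(=O)COc1ccc(Cl)cc1NC(=O)c1cc(Cl)cc(Br)c1` keeps all of compound 3 except one substituent: bromo in place of chloro on an aromatic carbon. It has bromo in place of chloro on an aromatic carbon, meta to a chloro group. Within the data shown here, no measured step makes this exchange, so the evidence is indirect. Even whole-group replacements moved the number only modestly, and the exchange in a 1.1-fold lower number from compound 2 to compound 3 (0.04 log units; within the scatter) stayed within the scatter. A much smaller edit is therefore expected to produce no step beyond the scatter in this assay. The expected change is a 1.1-fold lower number from compound 3 to compound 4 (0.05 log units; within the scatter). For compound 4 the estimated value is 65000 nM, within a range of 30000 nM to 130000 nM.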

Compound 4, half-maximal cytotoxic concentration: 114000 nM
Compound 4: the middle estimate sits 1.8-fold (0.24 log units) below what was measured, and the stated range covers the measured number.
By their numbers in this assay, from the lowest: compounds 3, 2 and 4 (each within the scatter of the next); then compound 1.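

In this assay, among these compounds, bromo in place of chloro on this aromatic carbon, meta to a chloro group, gives a 1.6-fold higher number from compound 3 to compound 4 (0.20 log units; within the scatter) and so leaves the exchange inseparable from the scatter, which is the first direct reading of a single-halogen change at this position. The 3-bromo-5-chlorophenyl group likewise cannot be told apart from the 2,5-dimethylphenyl group, with a 1.4-fold higher number from compound 2 to compound 4 (0.16 log units; within the scatter) as the step, yet it remains separated from the 3-fluorophenyl group by a 2.1-fold lower number from compound 1 to compound 4 (0.33 log units; beyond the scatter) as a modest step, so compound 1 still carries the highest number of the four and the other three form one group within the scatter. Nothing available bears on what lies behind these numbers.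

The compounds shown leave open whether a group of another kind at this position, such as an amine, a carboxylic acid or a methoxy group, would move the number beyond the scatter, as only halogens have been compared here. They also leave open whether iodo would behave as bromo does, and whether the bromo-for-chloro exchange would read the same with hydrogen in place of the remaining chloro group.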